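The source may hold more compounds than are shown below. What is called first, only, known or untested is meant among the compounds shown, and "the series" means these compounds.

Compound 3 `O=c1c(CSC(=S)N2CCOCC2)coc2ccccc12` is the point of departure. In a functional assay on MCF7 cells (Homo sapiens) for antiproliferative activity, read by MTT assay, with a stated time of 72 h (on this read-out lower numbers stand for stronger inhibition and higher numbers for weaker inhibition), compound 3 gives 4000 nM. Compound 2 `Cc1ccc2c(=O)c(CSC(=S)N(C(C)C)C(C)C)coc2c1` gives 6600 nM in this assay, a number within the usual scatter of that of compound 3, so the two cannot be ranked. Compound 1 `O=c1c(CSC(=S)N2CCCC2)coc2ccccc12` gives only a limit in this assay, > 25000 nM, which is the limit of > 25000 nM in this assay, at which 1 of the 3 values shown sits. Going by the values given here, the one measured step that changes the amine on the thiocarbonyl carbon is an at least 6.2-fold lower number from compound 1 to compound 3 (0.79 log units; beyond the scatter), so the identity of that amine can move the number by more than the scatter.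

Compound 4 `CC(C)N(C(=S)SCc1coc2ccccc2c1=O)C(C)C` differs from compound 3 by diisopropylamino in place of morpholin-4-yl on a thiocarbonyl carbon. Among the compounds with values here, compound 2 carries the same diisopropylamino group on a core that also bears a methyl, and its value of 6600 nM sits close to that of compound 3; no step between compound 2 and compound 4 is given, so their two values alone must guide the reading. The step from compound 1 to compound 3 was the only one beyond the scatter, and it ran in the opposite direction, away from a cyclic amine without the ring oxygen. Compound 4 is therefore expected to show a 1.4-fold higher number from compound 3 to compound 4 (0.14 log units; within the scatter), a small rise at most, and its estimated value in this assay is 5500 nM, with a range from 2500 nM to 14000 nM.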

Compound 4, half-maximal inhibitory concentration: > 30000 nM
Compound 4: a limit, no number (the forecaster's own chance of this, stated with the estimate: 10%); middle value at least 5.4-fold (0.73 log units) from the limit.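

Compound 4 gives a limit and not a number: the limit of > 30000 nM in this assay, at which 1 of the 4 values shown sits. On the shared core, diisopropylamino in place of morpholin-4-yl on a thiocarbonyl carbon gives an at least 7.5-fold higher number from compound 3 to compound 4 (0.87 log units; beyond the scatter), so this change matters as much as the earlier change from pyrrolidin-1-yl, and among compound 1, compound 3 and compound 4 only the morpholin-4-yl compound gives a number. Going by these compounds alone, the methyl also turns out to matter, a point the earlier compounds could not show: hydrogen in place of methyl on an aromatic carbon gives an at least 4.5-fold higher number from compound 2 to compound 4 (0.65 log units; beyond the scatter), so with diisopropylamino held constant the reading still depends on the rest of the molecule, and the amine alone does not settle it.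

Compound 1 and compound 4 are both limits, and the step between them cannot be read, which leaves the order of pyrrolidin-1-yl and diisopropylamino open. Also open, from the compounds shown here alone, is how methyl on the core would act alongside morpholin-4-yl, and how a piperidin-1-yl, piperazin-1-yl or dimethylamino group would read on the thiocarbonyl carbon.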